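Removing the Methyl from a Pyridinyl Ether

This account rests on a few compounds, and the source may have more. Where it says the series, first, only, none or still open, it means among the compounds named here.

Compound 1: `COC(=O)c1ccnc(O[C@@H]2CC[C@@H](C)N(C(=O)c3ccccc3-n3nccn3)C2)c1` 3.9 nM
Compound 2: `Cc1cccnc1O[C@@H]1CC[C@@H](C)N(C(=O)c2ccccc2-n2nccn2)C1` 621 nM

In an assay on CHO-K1 cells for displacement of a labelled ligand from Orexin receptor type 2 (Homo sapiens), read by radioligand binding (a lower number here means a stronger inhibitor, a higher number a weaker inhibitor), compound 2 gives the highest of the two numbers; its nearest neighbour is compound 1, with a 160-fold higher number from compound 1 to compound 2 (2.20 log units; beyond the scatter) separating them. Compound 3 `C[C@@H]1CC[C@@H](Oc2ccccn2)CN1C(=O)c1ccccc1-n1nccn1` differs from compound 2 by hydrogen in place of methyl on an aromatic carbon. Among the measured compounds shown here, the one measured step bears on it only loosely, since it exchanges a whole substituent on the pyridinyl ring rather than removing a methyl. The expectation is therefore a moderate shift, with some chance of improvement: a 3.1-fold lower number from compound 2 to compound 3 (0.49 log units; beyond the scatter). Compound 3 is estimated at 200 nM, within 40 nM to 1500 nM.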

Compound 3, inhibition constant: 2400 nM
Estimate against measurement, compound 3: 12-fold (1.08 log units) below; the whole stated range lies below it.
By their numbers in this assay, from the lowest: compound 1; then compound 2; then compound 3.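

Removing the methyl does not help: the change gives a 3.9-fold higher number from compound 2 to compound 3 (0.59 log units; beyond the scatter) and so, at this place two atoms from the ring nitrogen, methyl gives a lower number than hydrogen. With compound 3 as the unsubstituted reference, the methoxycarbonyl can be measured on its own, and the change gives a 620-fold higher number from compound 1 to compound 3 (2.79 log units; beyond the scatter) as that group gives way to hydrogen. Nothing available explains either step.

As far as these compounds go, it remains open whether an ethyl or a methoxy at the methyl's place would lower the number further. From the compounds shown here alone, it is equally open whether a carboxylic acid or an amide could stand in for the methoxycarbonyl.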